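A few compounds are considered here, and "the series" means these few. Any claim that something is new, unique, unknown or untested is made for them only; others in the source may bear on it.

Measured so far:
Compound 1 `CSc1ncc2cc(-c3ccccc3)c(-c3ccc(CNCCC(N)=O)cc3)nc2n1`: 1300 nM
Compound 2 `CSc1ncc2cc(-c3ccccc3)c(-c3ccc(CNCCCN4CCN(C)CC4)cc3)nc2n1`: 8920 nM

In an assay on isolated protein for inhibition of RAC-beta serine/threonine-protein kinase (Homo sapiens) (a higher number here means a weaker inhibitor, a lower number a stronger inhibitor), compound 2 gives 8920 nM, the higher of the two numbers, and its nearest neighbour is compound 1, which gives 1300 nM. Among the measured compounds shown here, the only step in hand is a 6.9-fold higher number from compound 1 to compound 2 (0.84 log units; beyond the scatter). Compound 3 `CSc1ncc2cc(-c3ccccc3)c(-c3ccc(CNCCCn4ccnc4)cc3)nc2n1` differs from compound 2 by 1H-imidazol-1-yl in place of 4-methylpiperazin-1-yl on a saturated chain carbon, three bonds along the chain from an amine nitrogen. For the measured compounds named here, no measured step follows this change, so the step of a 6.9-fold higher number from compound 1 to compound 2 (0.84 log units; beyond the scatter) only shows that the chain end matters at all. Compound 3 is therefore expected to land between its neighbours, at 4000 nM (range 1000 nM to 15000 nM), meaning an expected step of a 2.2-fold lower number from compound 2 to compound 3 (0.35 log units; beyond the scatter).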

Compound 3, half-maximal inhibitory concentration: 1510 nM
Beside the measured number, compound 3's estimate is 2.6-fold (0.42 log units) above it, within the range that was stated.
By their numbers in this assay, from the lowest: compounds 1 and 3 (each within the scatter of the next); then compound 2.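

In this assay, replacing 4-methylpiperazin-1-yl with 1H-imidazol-1-yl on the chain lowers the number (a 5.9-fold lower number from compound 2 to compound 3 (0.77 log units; beyond the scatter)), which shows that a ring at this chain end need not cost activity. Compared with the carbamoyl end, the (1H-imidazol-1-yl)methyl end shows no change beyond the scatter (a 1.2-fold higher number from compound 1 to compound 3 (0.07 log units; within the scatter)), so these two quite different ends cannot be told apart here. Nothing at hand explains why the two rings differ. Still open, going by these compounds, is how a morpholine, a dimethylamine or a carboxylic acid would fare at this chain end. A longer or shorter chain carrying the 1H-imidazol-1-yl group also remains untested in what is shown.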